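Working notes: trifluoromethyl for methoxy on the sulfonyl phenyl

The source may hold more compounds than are shown below. What is called first, only, known or untested is meant among the compounds shown, and "the series" means these compounds.

Measured so far in an assay on cells for inhibition of HSP60/HSP10 (Homo sapiens), with a stated time of 60 min; a lower number here means a stronger inhibitor, a higher number a weaker inhibitor:
compound 1 `O=S(=O)(Nc1ccc2oc(-c3ccccc3)nc2c1)c1cccc(O)c1` gives 76000 nM
compound 2 `COc1ccc(S(=O)(=O)Nc2ccc3oc(-c4ccccc4)nc3c2)cc1` gives > 100000 nM
compound 3 `O=S(=O)(Nc1ccc2oc(-c3ccccc3)nc2c1)c1ccccc1O` gives 85000 nM

The value of compound 2 is a limit of this assay and not a number; it is the limit of > 100000 nM in this assay, at which 1 of the 3 values shown sits. Compound 2 therefore stands at the top of the shown numbers, with compound 1 and compound 3 giving actual values beneath it. The steps among the three are small: an at least 1.3-fold higher number from compound 1 to compound 2 (0.11 log units; that floor lies within the scatter), an at least 1.1-fold lower number from compound 2 to compound 3 (0.07 log units; that floor lies within the scatter), and a 1.1-fold higher number from compound 1 to compound 3 (0.05 log units; within the scatter). The three compounds cannot be ordered against each other on these data.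

Compound 4 `O=S(=O)(Nc1ccc2oc(-c3ccccc3)nc2c1)c1ccc(C(F)(F)F)cc1` differs from compound 2 by trifluoromethyl in place of methoxy on an aromatic carbon. Among the measured compounds shown here, no measured step touches a trifluoromethyl; the measured steps only exchange hydroxy and methoxy on the phenyl on the sulfonyl sulfur, and every one of them lies within the scatter. Nothing in the series points to a step beyond the scatter in this assay in either direction, so the expected step is a number no higher from compound 2 to compound 4 (the limit leaves the size open). Compound 4 is estimated at 100000 nM, within 40000 nM to 300000 nM, with a real chance that this assay again reports only a limit for compound 4.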

Compound 4, half-maximal inhibitory concentration: > 100000 nM
Compound 4 was reported as a limit; the forecaster's own chance of this, stated with the estimate: 55%; the middle value sits exactly at the limit.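

In this assay compound 4 gives > 100000 nM, which is a limit and not a number. Among the compounds shown here, compound 2 also stands at a limit, so no step from compound 2 to compound 4 can be read: the limit of > 100000 nM in this assay, at which 2 of the 4 values shown sit. The compounds shown leave open whether trifluoromethyl in place of methoxy on an aromatic carbon changes the number in this assay, and in which direction.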